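From bromo to chloro on compound 2

This account rests on a few compounds, and the source may have more. Where it says the series, first, only, none or still open, it means among the compounds named here.

Going by the values given here, in a functional assay on CHO cells (Homo sapiens) for antiproliferative activity against CHO (Cricetulus griseus), read by sulforhodamine B assay, with a stated time of 48 h (a lower number here means a stronger inhibitor, a higher number a weaker inhibitor), compound 2 (`O=C1NCCN1c1ccc(S(=O)(=O)Nc2cccc(Br)c2)cc1`) gives 250 nM as the lower of the two numbers measured so far. Its nearest neighbour, compound 1 (`O=C1NCCN1c1ccc(S(=O)(=O)Nc2ccc3[nH]ccc3c2)cc1`), gives 1310 nM and the gap between them lies beyond the scatter. Among the compounds with values here, these two compounds differ in more than one place, so no measured single-place step is available as a guide. Compound 3 (`O=C1NCCN1c1ccc(S(=O)(=O)Nc2cccc(Cl)c2)cc1`) has chloro in place of bromo on an aromatic carbon and otherwise matches compound 2. In this assay no step beyond the scatter is expected, and no direction is firmly favoured. The expected step of a 1.2-fold higher number from compound 2 to compound 3 (0.08 log units; within the scatter) therefore stays small, with compound 2 at 250 nM as the only anchor. The estimated value for compound 3 is 300 nM with an expected range from 130 nM to 650 nM in this assay.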

Compound 3, half-maximal inhibitory concentration: 96 nM
Estimate against measurement, compound 3: 3.1-fold (0.49 log units) above; the measured number lies below the stated range.
By their numbers in this assay, from the lowest: compound 3; then compound 2; then compound 1.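

In this assay, going by these compounds alone, the change from 3-bromophenyl to 3-chlorophenyl gives a 2.6-fold lower number from compound 2 to compound 3 (0.42 log units; beyond the scatter), the first single-place step. This place, on an aromatic carbon meta to a large group, therefore responds to the exchange of one halogen for another, even though the two groups match in hydrogen-bond donors, hydrogen-bond acceptors and net charge. No measured evidence accounts for this difference between chloro and bromo.

With only two halogens compared at this place, a single step gives no ordering that can be extended to fluoro, methyl, methoxy or nitrile. Going by these compounds, it also remains open whether chloro would give a similar number at another aromatic carbon of that ring, or whether an amine or a carboxylic acid would be tolerated at this place.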